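A few compounds are considered here, and "the series" means these few. Any claim that something is new, unique, unknown or untested is made for them only; others in the source may bear on it.

Measured compounds in a functional assay on CFPAC-1 cells (Homo sapiens) for antiproliferative activity, read by MTT assay, with a stated time of 72 h; a higher number here means a weaker inhibitor, a lower number a stronger inhibitor:
- compound 1 `O=C1O[C@H]([C@@H](O)Cn2cc(-c3ccc(Br)cc3)nn2)C(OCc2ccccc2)=C1OCc1ccccc1` gives 5830 nM
- compound 2 `CCCCCCCCCCc1cn(C[C@H](O)[C@H]2OC(=O)C(OCc3ccccc3)=C2OCc2ccccc2)nn1` gives 40300 nM
- compound 3 `CC(C)(C)c1cn(C[C@H](O)[C@H]2OC(=O)C(OCc3ccccc3)=C2OCc2ccccc2)nn1` gives 54900 nM

Compound 3 holds the highest number of the three. Its nearest neighbour is compound 2, within the scatter: a 1.4-fold higher number from compound 2 to compound 3 (0.13 log units; within the scatter). Within the data shown here, the only step beyond the scatter that involves compound 3 runs from compound 1: a 9.4-fold higher number from compound 1 to compound 3 (0.97 log units; beyond the scatter). The parallel step to compound 2 is of similar size: a 6.9-fold higher number from compound 1 to compound 2 (0.84 log units; beyond the scatter).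

Compound 4 `O=C1O[C@H]([C@@H](O)Cn2cc(-c3cc(F)cc(F)c3)nn2)C(OCc2ccccc2)=C1OCc1ccccc1` is not yet measured. It differs from compound 3 in one place: 3,5-difluorophenyl in place of tert-butyl on an aromatic carbon. Among the measured compounds shown here, the step that bears on this most directly is the one from compound 1 to compound 3, in which 4-bromophenyl gave way to tert-butyl and the number rose by a 9.4-fold higher number from compound 1 to compound 3 (0.97 log units; beyond the scatter). The change from compound 3 to compound 4 brings a substituted phenyl back onto the same aromatic carbon, so a step of roughly that size in the opposite direction is expected in this assay, bringing the number back toward that of compound 1. For the measured compounds named here, no measured pair shows a 3,5-difluorophenyl against a 4-bromophenyl, so the spread is kept wide.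

The expected step is an 8.4-fold lower number from compound 3 to compound 4 (0.93 log units; beyond the scatter). For compound 4 the estimate in this assay is 6500 nM, within the range 2500 nM to 17000 nM.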

Compound 4, half-maximal inhibitory concentration: 62400 nM
For compound 4 the middle estimate is 9.6-fold (0.98 log units) below the measured one, outside the stated range (above it).
By their numbers in this assay, from the lowest: compound 1; then compounds 2, 3 and 4 (each within the scatter of the next).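

In this assay, a phenyl ring on this aromatic carbon does not by itself set a compound apart from the alkyl-bearing ones: 3,5-difluorophenyl in place of tert-butyl gives a 1.1-fold higher number from compound 3 to compound 4 (0.06 log units; within the scatter), and in place of decyl it gives a 1.5-fold higher number from compound 2 to compound 4 (0.19 log units; within the scatter). Among the four groups shown, the lower number is tied to 4-bromophenyl alone and not to aryl substitution in general, as exchanging 4-bromophenyl for 3,5-difluorophenyl gives an 11-fold higher number from compound 1 to compound 4 (1.03 log units; beyond the scatter), leaving compound 4 with the alkyl-bearing compounds and compound 1 as the only one apart. No measured property of these compounds is at hand to account for this result.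

The two aryl groups differ in both the halogen and its place on the phenyl ring, so the compounds shown cannot separate these two changes. Also open, on these data alone, is how an unsubstituted phenyl, a 4-chlorophenyl or a chain ending in an amine on this carbon would compare in this assay.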